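The source may hold more compounds than are shown below. What is called first, only, known or untested is meant among the compounds shown, and "the series" means these compounds.

For the measured compounds named here, compound 2 `O=c1nc2oc(C3CC3)c(C#CC3CC3)c2cn1Cc1cn(-c2ccc(Cl)cc2)nn1` gives 35400 nM in a functional assay on CFPAC-1 cells (Homo sapiens) for antiproliferative activity, read by MTT assay, with a stated time of 72 h (a lower number here means a stronger inhibitor, a higher number a weaker inhibitor), and that is the only definite number in this small set. Compound 1 `O=c1nc2oc(CCCCl)cc2cn1Cc1cn(-c2ccc(Cl)cc2)nn1` gives > 100000 nM in this assay, which is a limit of the measurement and not a number, namely (the limit of > 100000 nM in this assay, at which 1 of the 2 values shown sits). Compound 2 therefore stands alone with a measured potency, and it is a weak inhibitor.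

Compound 3 `O=c1nc2oc(C3CC3)cc2cn1Cc1cn(-c2ccc(Cl)cc2)nn1` differs from compound 2 in one place, (hydrogen in place of 2-cyclopropylethynyl on an aromatic carbon), that is, hydrogen in place of 2-cyclopropylethynyl on an aromatic carbon. Going by the values given here, no pair of measured compounds shows this step, so its size is not known from the data. The expectation is that the step from compound 2 to compound 3 in this assay is a 2.0-fold higher number from compound 2 to compound 3 (0.30 log units; within the scatter), toward a weaker inhibitor, with a fair chance that only a limit is reported. Compound 3 is estimated at 70000 nM, within a range from 25000 nM to 200000 nM.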

Compound 3, half-maximal inhibitory concentration: > 100000 nM
Compound 3 was reported as a limit (the forecaster's own chance of this, stated with the estimate: 45%); middle value at least 1.4-fold (0.15 log units) away from the limit.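

Putting hydrogen in place of the 2-cyclopropylethynyl group gives an at least 2.8-fold higher number from compound 2 to compound 3 (0.45 log units; beyond the scatter) in this assay and so shows that this aromatic carbon, two ring bonds from the ring oxygen, is not indifferent to what it carries. Among these compounds, the only definite number belongs to compound 2, the one compound bearing this group. The value of compound 3 is a limit of the assay and not a number, and the step between compound 1 and compound 3 cannot be read: the limit of > 100000 nM in this assay, at which 2 of the 3 values shown sit.

The compounds shown do not separate the part played by the triple bond from that of the cyclopropyl ring at its end. As far as these compounds go, whether plain ethynyl, phenylethynyl or a saturated propyl chain at this carbon would match or exceed compound 2 remains open.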